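The source may hold more compounds than are shown below. What is called first, only, known or untested is meant among the compounds shown, and "the series" means these compounds.

Among the compounds with values here, compound 1 `COc1cc(/C=C/C(=O)c2cc(-c3cc(OC)c(OC)c(OC)c3)n3nc(-c4ccccc4)cc3n2)cc(OC)c1OC` is one of three compounds measured in an ADME assay on HEK293 cells (Homo sapiens) for antiproliferative activity, read by MTT assay, with a stated time of 24 h (on this read-out higher numbers stand for weaker inhibition and lower numbers for stronger inhibition), where compound 1 gives 41000 nM. That is the lowest of the three numbers, but the gaps to the others fall within the scatter: compound 2 `COc1ccc(-c2cc(C(=O)/C=C/c3cc(OC)c(OC)c(OC)c3)nc3cc(-c4ccccc4)nn23)cc1OC` gives 46800 nM in this assay, and compound 3 `COc1ccc(-c2cc(/C=C/C(=O)c3ccccc3)nc3cc(-c4ccccc4)nn23)cc1OC` gives 51200 nM. Within the data shown here, the one single-point step among them, a 1.1-fold higher number from compound 1 to compound 2 (0.06 log units; within the scatter), amounts to no real change.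

Compound 4 `COc1cc(-c2cc(C(=O)/C=C/c3ccc(C)cc3)nc3cc(-c4ccccc4)nn23)cc(OC)c1OC` differs from compound 1 in one place: 4-methylphenyl in place of 3,4,5-trimethoxyphenyl on a double-bonded chain carbon bound to a double-bonded chain carbon. Among the measured compounds shown here, no measured step covers this exact exchange. For the measured compounds named here, the nearest guidance is that compound 3, which carries a bare phenyl on the chain in place of the trimethoxyphenyl of compound 2, sits within the scatter of compound 2 and of compound 1, so removing the three methoxy groups from that ring has not shifted the number so far. On that basis, the step of a 1.2-fold higher number from compound 1 to compound 4 (0.09 log units; within the scatter) is expected to stay within the scatter, with perhaps a slight drift upward. Compound 4 is therefore estimated at 50000 nM, in a range from 22000 nM to 110000 nM.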

Compound 4, half-maximal inhibitory concentration: 56100 nM
The estimate for compound 4 lay 1.1-fold (0.05 log units) below the measured number; the measured number falls inside the stated range.
By their numbers in this assay, from the lowest: compounds 1, 2, 3 and 4 (each within the scatter of the next).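

The exchange on a double-bonded chain carbon bound to a double-bonded chain carbon gives a 1.4-fold higher number from compound 1 to compound 4 (0.14 log units; within the scatter) in this assay. This is the one direct test of this position: the group shrinks from 12 heavy atoms to 7 and from 3 hydrogen-bond acceptors to 0, yet the number does not really move, so in this pair the three methoxy groups can be replaced by a single methyl without a real change. Nothing measured here explains why the number holds.

From the compounds shown here alone, it remains open how the number would respond to an amine or a carboxylic acid on this ring, or to a longer chain in its place. Going by these compounds, every number so far lies within the scatter of the next, so it is also open whether any change at this position can move the number in this assay at all.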